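The compounds below may be only part of what the source reports. "The series", "measured", "known", "first", "only" and "open" are said of these compounds alone.

Of the compounds shown here, two on the shared core have been tested so far in a functional assay on HeLa cells (Homo sapiens) for inhibition, read by MTT assay, with a stated time of 72 h; on this read-out higher numbers stand for weaker inhibition and lower numbers for stronger inhibition. Going by the values given here, compound 2 `COc1cc(OC)c(OC)cc1/C=C/C(=O)c1ccc(C)cc1` gives 42200 nM, the only actual number available. Compound 1 `COc1cc(OC)c(OC)cc1/C=C/C(=O)c1ccc(-c2c[nH]cn2)cc1` is reported as > 150000 nM, and this is a limit of the assay, not a number. Among the compounds with values here, the single measured step is an at least 3.5-fold lower number from compound 1 to compound 2 (0.55 log units; beyond the scatter), with methyl in place of 1H-imidazol-4-yl on an aromatic carbon. From the compounds shown here alone, one end of that step stands at the limit of > 150000 nM in this assay, at which 1 of the 2 values shown sits, so its full size remains unknown.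

Compound 3 `COc1cc(OC)c(OC)cc1/C=C/C(=O)c1ccc([N+](=O)[O-])cc1` carries nitro in place of methyl on an aromatic carbon, para to a large group: nitro in place of methyl on an aromatic carbon. The measured step involves methyl but not nitro, so it gives no direct guide to the size or direction of this change. Compound 2, at 42200 nM, therefore serves as the anchor, and no shift beyond the scatter is expected in this assay. The expected step is a 1.2-fold lower number from compound 2 to compound 3 (0.08 log units; within the scatter). For compound 3 the estimated value is 35000 nM, with an expected range from 10000 nM to 120000 nM.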

Compound 3, half-maximal inhibitory concentration: > 150000 nM
Compound 3 gave a limit, no number; the forecaster's own chance of this, stated with the estimate: 15%; at least 4.2-fold (0.63 log units) between middle value and limit.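

Nitro in place of methyl on an aromatic carbon, para to a large group, gives an at least 3.5-fold higher number from compound 2 to compound 3 (0.55 log units; beyond the scatter), so this position does not tolerate every replacement of methyl, and 1H-imidazol-4-yl is no longer the only group shown to give a higher number than methyl. From the compounds shown here alone, compound 1 and compound 3 now both stand at a limit of the assay rather than at a number: the limit of > 150000 nM in this assay, at which 2 of the 3 values shown sit. The step between these two compounds cannot be read, so their groups cannot be ranked against each other, and the full size of the change from methyl to nitro remains unknown.

In this assay, going by these compounds alone, compound 2, at 42200 nM, remains the only compound with an actual number, so the shared core has no second measured point against which to judge a change at this place. What the compounds shown leave open is how an amine, a hydroxyl, a chlorine atom or a longer alkyl chain would read at this position, and whether any group there gives a lower number than methyl.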